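Phenoxymethyl for benzyl on a bis-aziridinyl quinone core

The compounds below may be only part of what the source reports. "The series", "measured", "known", "first", "only" and "open" are said of these compounds alone.

Measured compounds:
compound 1 `CC1=C(N2CC2)C(=O)C(Cc2ccccc2)=C(N2CC2)C1=O`, 4.74
compound 2 `CC(=O)C1=C(N2CC2)C(=O)C(C)=C(N2CC2)C1=O`, 3.94
compound 3 `COC(CO)C1=C(N2CC2)C(=O)C(C)=C(N2CC2)C1=O`, 6.05

In a functional assay on L1210 cells (Mus musculus), with a stated time of 1 days (on this read-out higher numbers stand for higher potency (the scale is a negative logarithm) and lower numbers for lower potency), compound 1 stands second highest of the three numbers. The step of a number 0.80 log units lower from compound 1 to compound 2 (beyond the scatter) goes down, while the step of a number 1.31 log units higher from compound 1 to compound 3 (beyond the scatter) goes up, both beyond the scatter. Compound 4 `CC1=C(N2CC2)C(=O)C(COc2ccccc2)=C(N2CC2)C1=O` differs from compound 1 by phenoxy in place of phenyl on a saturated chain carbon bound to a double-bonded ring carbon. Going by the values given here, no measured step swaps phenyl for phenoxy, so neither step bears on it directly; both show that replacing the side chain on this core shifts this assay by a modest to large amount. With the aromatic ring kept and only an oxygen entering, compound 4 is expected to give a small rise, a number 0.26 log units higher from compound 1 to compound 4 (within the scatter), of uncertain direction. Compound 4 is therefore estimated at 5, in the range 4.3 to 5.8.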

Compound 4, logarithm of the reciprocal of the active concentration, log(1/C): 4.68
The estimate for compound 4 lay 0.32 log units above the measured number, and the stated range covers the measured number.
By their numbers in this assay, from the lowest: compound 2; then compounds 4 and 1 (each within the scatter of the next); then compound 3.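

In this assay, phenoxy in place of phenyl on a saturated chain carbon bound to a double-bonded ring carbon gives a number 0.06 log units lower from compound 1 to compound 4 (within the scatter), so this change leaves the number within the scatter. Unlike the acetyl and 2-hydroxy-1-methoxyethyl replacements of benzyl, this one keeps the aromatic ring and adds a hydrogen-bond acceptor without a step beyond the scatter. No available evidence accounts for this result. On these data alone, whether an amine or a carboxylic acid in place of phenoxy on that carbon would move the number stays open, as does the outcome of a longer chain there.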